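A few compounds are considered here, and "the series" means these few. Any claim that something is new, unique, unknown or untested is made for them only; others in the source may bear on it.

Working notes on the series. Of the compounds shown here, three have been measured in a functional assay on HeLa cells (Homo sapiens) for antiproliferative activity, read by MTT assay, with a stated time of 48 h; on this read-out higher numbers stand for weaker inhibition and lower numbers for stronger inhibition: compound 1 `CSCC[C@H](NC(=O)c1cc2ccccc2cn1)C(=O)OCc1ccccc1` gives 309 nM, compound 2 `NCCCC[C@H](NC(=O)c1cc2ccccc2cn1)C(=O)OCc1ccccc1` gives 196 nM, and compound 3 `CC[C@@H](C)[C@H](NC(=O)c1cc2ccccc2cn1)C(=O)OCc1ccccc1` gives 185 nM. Compound 2 stands with the second highest of the three numbers; its nearest neighbour is compound 3 and its furthest is compound 1, and every step among these compounds lies within the scatter: a 1.6-fold lower number from compound 1 to compound 2 (0.20 log units; within the scatter), a 1.7-fold lower number from compound 1 to compound 3 (0.22 log units; within the scatter), a 1.1-fold lower number from compound 2 to compound 3 (0.03 log units; within the scatter). No change of side chain seen so far has moved this assay beyond the scatter.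

The next compound, compound 4 `O=C(CC[C@H](NC(=O)c1cc2ccccc2cn1)C(=O)OCc1ccccc1)OCc1ccccc1`, is derived from compound 2 by the change (benzyloxycarbonyl in place of 2-aminoethyl on a saturated chain carbon, three bonds along the chain from an amide-type nitrogen and a carbonyl carbon). For the measured compounds named here, two measured steps touch the same side chain: the exchange at the same place, a 1.6-fold lower number from compound 1 to compound 2 (0.20 log units; within the scatter), and the exchange of the whole chain, a 1.1-fold lower number from compound 2 to compound 3 (0.03 log units; within the scatter). Going by the values given here, neither carries a benzyloxycarbonyl group, so the new group itself has no precedent here. Given that every side-chain change so far stayed within the scatter, compound 4 is expected to show no step beyond the scatter, a 1.2-fold higher number from compound 2 to compound 4 (0.07 log units; within the scatter). The estimate for compound 4 is 230 nM, with a range of 100 nM to 550 nM.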

Compound 4, half-maximal inhibitory concentration: 214 nM
For compound 4 the middle estimate is 1.1-fold (0.03 log units) above the measured one; the range from low to high includes it.
By their numbers in this assay, from the lowest: compounds 3, 2, 4 and 1 (each within the scatter of the next).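

The change at this place, on a saturated chain carbon three bonds along the chain from an amide-type nitrogen and a carbonyl carbon, swaps 2-aminoethyl for the larger benzyloxycarbonyl with its aromatic ring, and in this assay it gives a 1.1-fold higher number from compound 2 to compound 4 (0.04 log units; within the scatter). The other two steps, a 1.2-fold higher number from compound 3 to compound 4 (0.06 log units; within the scatter) and a 1.4-fold lower number from compound 1 to compound 4 (0.16 log units; within the scatter), also stay within the scatter, so this side chain now accepts an aromatic ester and loses its nitrogen with no step beyond the scatter among the four compounds. No evidence available bears on why the read-out stays within the scatter across these side chains.

As far as these compounds go, whether a free carboxylic acid or a longer chain at this place would step beyond the scatter remains open. From the compounds shown here alone, the effect of replacing the benzyl ester shared by all four compounds also remains open.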